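Solubility of a phenoxy analogue with tert-butyl in place of methoxy

The source may report more compounds than this note shows. Statements on the series, on what has been measured and on what is new or still open speak of the compounds shown alone.

Compound 1 `COc1cccc(CNCCCNc2ccnc3cc(CCC(C)C)ccc23)c1O`: 4200 nM
Compound 2 `COc1ccc(Oc2ccc3c(NCCCNCc4cccc(OC)c4O)ccnc3c2)cc1`: 14500 nM

In a physicochemical assay for solubility, with a stated time of 18 h, at pH 7.4 (a lower number here means a less soluble compound, a higher number a more soluble compound), compound 2 gives 14500 nM and stands highest of the two numbers; the nearest is compound 1, which gives 4200 nM in this assay. For the measured compounds named here, the one measured step, a 3.5-fold higher number from compound 1 to compound 2 (0.54 log units; beyond the scatter), is the only comparison available. Compound 3 `COc1cccc(CNCCCNc2ccnc3cc(Oc4ccc(C(C)(C)C)cc4)ccc23)c1O` differs from compound 2 as follows: tert-butyl in place of methoxy on an aromatic carbon. Going by the values given here, that change is not the same as the measured step, which exchanged a whole group on the shared core; no measured pair covers an exchange of methoxy for tert-butyl, so the measured step bears only loosely on this one. The estimate for compound 3 is therefore uncertain, and compound 3 is expected to give 6000 nM in this assay, with a range of 1500 nM to 15000 nM. The step this means, a 2.4-fold lower number from compound 2 to compound 3 (0.38 log units; beyond the scatter), is an expectation of a modest move toward a lower number, and may well fall within the scatter.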

Compound 3, solubility: 14500 nM
Compound 3: the middle estimate sits 2.4-fold (0.38 log units) below what was measured; measured number inside the range.
By their numbers in this assay, from the lowest: compound 1; then compounds 2 and 3 (each within the scatter of the next).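

In this assay, exchanging 4-methoxyphenoxy for 4-(tert-butyl)phenoxy gives no change at the digits printed from compound 2 to compound 3 (within the scatter), so at this position a group of four carbons in place of methoxy, with one hydrogen-bond acceptor fewer, leaves the reading unmoved. Putting 4-(tert-butyl)phenoxy in place of isopentyl gives a 3.5-fold higher number from compound 1 to compound 3 (0.54 log units; beyond the scatter), which gives a second case alongside the earlier step with 4-methoxyphenoxy, a 3.5-fold higher number from compound 1 to compound 2 (0.54 log units; beyond the scatter). No accompanying measurement offers an explanation for either result.

The compounds shown leave open whether the reading stays level with an amine or a carboxylic acid on this aromatic carbon, as both groups compared here carry no net charge. They also leave open how a plain phenoxy group, with only hydrogen at that carbon, would compare.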